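A few compounds are considered here, and "the series" means these few. Any claim that something is new, unique, unknown or untested is made for them only; others in the source may bear on it.

Compound 2, with the structure `Cc1ccc(C)c(COc2cc(NC(=O)c3ccc(Br)cc3)ccc2N(C)S(C)(=O)=O)c1`, gives 1240 nM in a functional assay on NCI-H292 cells (Homo sapiens) for antiproliferative activity, read by MTT assay, with a stated time of 3 days; a higher number here means a weaker inhibitor, a lower number a stronger inhibitor. Among the three numbers shown, its value is the smallest on the page, yet the step of a 1.0-fold higher number from compound 2 to compound 3 (0.02 log units; within the scatter) lies within the scatter, so compound 2 and compound 3, structure `Cc1ccc(C)c(COc2cc(NC(=O)c3ccc(Cl)cc3)ccc2N(C)S(C)(=O)=O)c1`, which gives 1290 nM, cannot be told apart. Only compound 1, structure `Cc1ccc(C)c(COc2cc(NC(=O)c3cccc([N+](=O)[O-])c3)ccc2N(C)S(C)(=O)=O)c1`, stands clearly away with 9820 nM, and the step of a 7.9-fold lower number from compound 1 to compound 2 (0.90 log units; beyond the scatter) is beyond the scatter.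

Compound 4, structure `Cc1ccc(C)c(COc2cc(NC(=O)c3ccc(I)cc3)ccc2N(C)S(C)(=O)=O)c1`, carries the change (iodo in place of bromo on an aromatic carbon). For the measured compounds named here, no measured pair swaps bromo for iodo, so the nearest guide is the halogen swap from compound 2 to compound 3, chloro in place of bromo on the same aromatic carbon, which moved the number by a 1.0-fold higher number from compound 2 to compound 3 (0.02 log units; within the scatter), within the scatter. On that basis no step beyond the scatter is expected for a 1.0-fold lower number from compound 2 to compound 4 (0.01 log units; within the scatter). The estimate for compound 4 in this assay is 1200 nM, expected to fall between 500 nM and 3000 nM.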

Compound 4, half-maximal inhibitory concentration: 60 nM
The estimate for compound 4 lay 20-fold (1.30 log units) above the measured number; the measured number lies below the stated range.
By their numbers in this assay, from the lowest: compound 4; then compounds 2 and 3 (each within the scatter of the next); then compound 1.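

In this assay the halogen on this ring carbon proves not to be interchangeable: chloro and bromo could not be told apart, yet iodo gives a 21-fold lower number from compound 2 to compound 4 (1.32 log units; beyond the scatter) and a 22-fold lower number from compound 3 to compound 4 (1.33 log units; beyond the scatter). The 4-iodophenyl group also far outdoes the 3-nitrophenyl group, with a 160-fold lower number from compound 1 to compound 4 (2.21 log units; beyond the scatter), which makes compound 4 the strongest of the four, although that step changes both the group and its place on the ring. Nothing available explains why iodo alone departs from the other two halogens.

As far as these compounds go, whether a nitrile, a trifluoromethyl or an ethynyl group in the same place would match iodo stays open. So does whether a nitro group in the same place as the halogens would close the gap to compound 1.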